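Imide series: azo-bearing group in place of phenyl

The source may report more compounds than this note shows. Statements on the series, on what has been measured and on what is new or still open speak of the compounds shown alone.

Measured compounds:
compound 1 `O=C1c2ccccc2C(=O)N1c1ccc(-c2ccccc2)cc1` — 40400 nM
compound 2 `Cc1ccc2c(c1)C(=O)N(c1ccc(-c3ccccc3)cc1)C2=O` — 104000 nM

In a functional assay on HEp-2 cells (Homo sapiens) for cytotoxicity, read by MTT assay, with a stated time of 24 h (a lower number here means a stronger inhibitor, a higher number a weaker inhibitor), compound 1 gives 40400 nM and compound 2 gives 104000 nM. Within the data shown here, compound 2 has the higher of the two numbers; its only neighbour is compound 1, and the step of a 2.6-fold higher number from compound 1 to compound 2 (0.41 log units; beyond the scatter) is modest. Compound 3 `Cc1ccc2c(c1)C(=O)N(c1ccc(/N=N\c3ccccc3)cc1)C2=O` differs from compound 2 by a group of 8 heavy atoms (6 carbon, 2 nitrogen; one six-membered aromatic ring of carbon only) in place of a group of 6 heavy atoms (6 carbon; one six-membered aromatic ring of carbon only), on an aromatic carbon. Among the measured compounds shown here, the one measured step concerns the methyl and does not bear on this exchange, so no step beyond the scatter is expected in this assay. Compound 3 is estimated at 100000 nM (range 30000 nM to 300000 nM), which means an expected step of a 1.0-fold lower number from compound 2 to compound 3 (0.02 log units; within the scatter).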

Compound 3, half-maximal inhibitory concentration: 104000 nM
For compound 3 the middle estimate is 1.0-fold (0.02 log units) below the measured one, within the range that was stated.
By their numbers in this assay, from the lowest: compound 1; then compounds 2 and 3 (each within the scatter of the next).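

In this assay the azo-bearing group in place of phenyl gives no change at the digits printed from compound 2 to compound 3 (within the scatter) at this aromatic carbon, para to a large group. Among these compounds, the earlier step concerned only the methyl, so this is the first reading at this position, and here the larger group leaves the number unmoved at the digits printed. No measured evidence bears on this result. On these data alone, whether an amine or a carboxylic acid on this carbon would shift the number remains open. So does the effect of the azo-bearing group on the core of compound 1.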